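The source may report more compounds than this note shows. Statements on the series, on what has been measured and on what is new or still open speak of the compounds shown alone.

Measured so far:
Compound 1 `COc1ccc(S(=O)(=O)N2CCc3cccc(-c4cccnc4)c32)cc1`: 95.9 nM
Compound 2 `COc1ccc(S(=O)(=O)N2CCc3cccc(-c4ccc(F)c(F)c4)c32)cc1`: 45 nM

In a functional assay on KB cells (Homo sapiens) for inhibition, with a stated time of 72 h (on this read-out lower numbers stand for stronger inhibition and higher numbers for weaker inhibition), compound 2 gives 45 nM, the lowest of the two numbers; compound 1 gives 95.9 nM. For the measured compounds named here, the single step measured, a 2.1-fold lower number from compound 1 to compound 2 (0.33 log units; beyond the scatter), came with 3,4-difluorophenyl in place of pyridin-3-yl on an aromatic carbon. Compound 3 `COc1ccc(S(=O)(=O)N2CCc3cccc(-c4cccc(F)c4)c32)cc1` differs from compound 2 by hydrogen in place of fluoro on an aromatic carbon. Going by the values given here, no measured step bears directly on this change: the one step known swaps the whole ring, so it says nothing about one fluoro taken away from 3,4-difluorophenyl. With only that to go on, the step in this assay from compound 2 to compound 3 is expected to be small, at most a modest rise, and is estimated as a 1.3-fold higher number from compound 2 to compound 3 (0.12 log units; within the scatter). Compound 3 is therefore expected to give about 60 nM, in a range from 30 nM to 130 nM.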

Compound 3, half-maximal inhibitory concentration: 98.5 nM
Compound 3: middle estimate off by 1.6-fold (0.22 log units), on the low side; the measured number falls inside the stated range.
By their numbers in this assay, from the lowest: compound 2; then compounds 1 and 3 (each within the scatter of the next).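

In this assay, taking away the fluoro para to a large group gave a 2.2-fold higher number from compound 2 to compound 3 (0.34 log units; beyond the scatter), so this one atom counts for a step beyond the scatter, something the whole-ring swap could not show. Placing 3-fluorophenyl where pyridin-3-yl stood gave a 1.0-fold higher number from compound 1 to compound 3 (0.01 log units; within the scatter), within the scatter, so among these compounds the lower number belongs only to 3,4-difluorophenyl and the remaining fluoro alone does not reproduce it. Nothing available explains either step.

The compounds shown leave open whether the remaining fluoro contributes at all, as a plain phenyl group would be needed to read that. They also leave open whether a chloro, a methoxy or an amine in place of the fluoro that was removed would keep the lower number.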